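The source may report more compounds than this note shows. Statements on the series, on what has been measured and on what is new or still open speak of the compounds shown alone.

Three compounds share one core and end in the same hydroxycarbamoyl group, and they differ only in the length of the saturated chain between the two. All belong to a functional assay on CNE-2 cells (Homo sapiens) for inhibition, read by MTT assay, with a stated time of 72 h; a lower number here means a stronger inhibitor, a higher number a weaker inhibitor. Compound 1 `Nc1ncnc2c1c(-c1cnc3[nH]ccc3c1)nn2CC(=O)NO`, with the shortest chain, gives > 150000 nM, and that figure is a limit of the assay, not a number. Within the data shown here, compound 2 `Nc1ncnc2c1c(-c1cnc3[nH]ccc3c1)nn2CCCCCCCCCC(=O)NO`, with the longest chain, gives 2200 nM, the only true number so far, so no measured step exists to scale from.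

Compound 3 `Nc1ncnc2c1c(-c1cnc3[nH]ccc3c1)nn2CCCCCCC(=O)NO` shortens the chain of compound 2: hydroxycarbamoyl in place of 3-(hydroxycarbamoyl)propyl on a saturated chain carbon, six bonds along the chain from an aromatic nitrogen. In words, hydroxycarbamoyl stands in place of 3-(hydroxycarbamoyl)propyl on a saturated chain carbon, six bonds along the chain from an aromatic nitrogen.

The chain of compound 3 remains longer than that of compound 1, and compound 2 at 2200 nM is the one firm anchor, so no change beyond the usual scatter is the best expectation in this assay, though a larger move either way remains possible. The expected step of a 1.2-fold lower number from compound 2 to compound 3 (0.09 log units; within the scatter) is therefore small. For compound 3 the estimated half-maximal inhibitory concentration is 1800 nM, with an expected range of 400 nM to 10000 nM.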

Compound 3, half-maximal inhibitory concentration: 19500 nM
Estimate against measurement, compound 3: 11-fold (1.03 log units) below; measured number above the stated range.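

In this assay the length of the chain matters at this position, since the step is an 8.9-fold higher number from compound 2 to compound 3 (0.95 log units; beyond the scatter) and goes beyond the usual scatter, so the change from 3-(hydroxycarbamoyl)propyl to hydroxycarbamoyl on a saturated chain carbon, six bonds along the chain from an aromatic nitrogen, is not a neutral trim. Measured against the shortest chain, the step is an at least 7.6-fold lower number from compound 1 to compound 3 (0.88 log units; beyond the scatter) and also goes beyond the scatter, which places compound 3 as a true middle point, and across these three compounds the number falls as the chain grows, with none going against that order. Compound 1 gives > 150000 nM, which is a limit of the assay and not a number, so the step that starts from it fixes only a minimum size: the limit of > 150000 nM in this assay, at which 1 of the 3 values shown sits.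

Still open, going by these compounds, is how the number moves at the chain lengths in between, and whether a longer chain than that of compound 2 would lower it further or raise it again. Also open, on these data alone, is how much depends on the end group itself, which a carboxylic acid or a primary amide at the end of the same chain would address.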